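Cytotoxicity notes: vinyl dihydrofuran amides, compound 4

The source may hold more compounds than are shown below. What is called first, only, known or untested is meant among the compounds shown, and "the series" means these compounds.

Measured so far:
compound 1 `C=CC1=C(C(=O)NCc2ccccc2)C(c2ccc(Cl)c(Cl)c2)OC1`: in a functional assay on HeLa cells (Homo sapiens) for cytotoxicity, read by MTT assay, with a stated time of 24 h (on this read-out lower numbers stand for stronger inhibition and higher numbers for weaker inhibition), compound 1 gives only a limit, > 100000 nM.
compound 2 `C=CC1=C(C(=O)Nc2cccc(C)c2)C(c2ccc(F)cc2)OC1`: in this assay compound 2 is reported as "not active" (no number reported).
compound 3 `C=CC1=C(C(=O)NCCC)C(c2ccc(Cl)c(Cl)c2)OC1`: in this assay compound 3 gives only a limit, > 100000 nM.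

Compound 2 therefore has no number in this assay at all. For the measured compounds named here, two of the three values sit at the limit of > 100000 nM in this assay, at which 2 of the 3 values shown sit, so no single compound in the set shows measurable inhibition.

Compound 4 `C=CC1=C(C(=O)Nc2ccccc2)C(c2ccc(F)cc2)OC1` is reached from compound 2 by hydrogen in place of methyl on an aromatic carbon. Going by the values given here, the only step with a measured pair, a step that the two limits leave unreadable from compound 1 to compound 3, changes a different group on the amide side and its size cannot be read from two limits; it does not bear on the change from compound 2 to compound 4. Among the compounds with values here, no measured step addresses the loss of the methyl, so no direction beyond scatter can be expected.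

Compound 4 is expected to remain without measurable inhibition in this assay, estimated at 100000 nM within 30000 nM to 300000 nM.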

Compound 4, half-maximal inhibitory concentration: > 100000 nM
Compound 4: only a limit was reported (the forecaster's own chance of this, stated with the estimate: 80%); the middle value lies on the limit itself.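

No new step can be read from compound 2 to compound 4, since compound 2 carries no number and compound 4 gives only a limit. The compounds shown leave open which change to the shared core, if any, gives measurable inhibition.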